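Trading a Sulfonyl for a Carbonyl on the Chain

A few compounds are considered here, and "the series" means these few. Any claim that something is new, unique, unknown or untested is made for them only; others in the source may bear on it.

Three compounds share a core in which an indole-like bicycle carries a phenyl group and a short unsaturated chain, and all three were tested in a functional assay on BT-549 cells (Homo sapiens) for inhibition, read by sulforhodamine B assay, with a stated time of 48 h; a lower number here means a stronger inhibitor of growth, a higher number a weaker inhibitor of growth. Compound 1 `COc1ccc(-c2[nH]c3ccccc3c2/C=C(\C#N)S(=O)(=O)c2ccccc2)cc1` gives 1600 nM in this assay. Compound 2 `CC(=O)/C(=C\c1c(-c2ccccc2)[nH]c2ccccc12)S(=O)(=O)c1ccccc1` gives 1900 nM. Compound 3 `N#C/C(=C\c1c(-c2ccccc2)[nH]c2ccccc12)S(=O)(=O)c1ccccc1` gives 11600 nM, the highest of the three numbers, so compound 3 is the weakest growth inhibitor among them. The step of a 7.3-fold higher number from compound 1 to compound 3 (0.86 log units; beyond the scatter) and the step of a 6.1-fold higher number from compound 2 to compound 3 (0.79 log units; beyond the scatter) both lie beyond the scatter, each a modest rise.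

Compound 4 `N#C/C(=C\c1c(-c2ccccc2)[nH]c2ccccc12)C(=O)c1ccccc1` differs from compound 3 in one place: benzoyl in place of phenylsulfonyl on a double-bonded chain carbon bound to a double-bonded chain carbon and a triple-bonded carbon. Neither measured step touches this position. The step from compound 1 to compound 3 concerns a substituent on an aromatic ring, and the step from compound 2 to compound 3 concerns the other chain carbon, so neither tells how swapping the phenylsulfonyl for a benzoyl will act in this assay. With no guide from the data, the expected step of a 1.5-fold lower number from compound 3 to compound 4 (0.16 log units; within the scatter) is small and of uncertain direction. Compound 4 is therefore estimated at 8000 nM in this assay, within a range of 2500 nM to 25000 nM.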

Compound 4, concentration for 50% growth inhibition: 3000 nM
Compound 4: the middle estimate sits 2.7-fold (0.43 log units) above what was measured; measured number inside the range.
By their numbers in this assay, from the lowest: compounds 1, 2 and 4 (each within the scatter of the next); then compound 3.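

The chain carbon bearing the nitrile proves sensitive to the group it carries: in this assay, benzoyl in place of phenylsulfonyl gives a 3.9-fold lower number from compound 3 to compound 4 (0.59 log units; beyond the scatter), a modest step but a real one. Until now, the steps shown concerned only the aromatic substituent and the group on the other side of the chain, so this is the first sign that the phenylsulfonyl itself can be exchanged with a gain in growth inhibition. The swap keeps the six-membered aromatic ring of carbon only and changes the link that joins it to the chain, yet no measurement here accounts for the lower number.

On these data alone, whether the same exchange would give a similar step on compound 1, with its methoxy group, or on compound 2, with its acetyl group, remains open. Also open, as far as these compounds go, is how this chain carbon would respond to groups unlike these two, such as a carboxylic acid, an amide or a chain ending in an amine.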